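The source may report more compounds than this note shows. Statements on the series, on what has been measured and on what is new or still open speak of the compounds shown alone.

Working notes on the series. Compound 1 `COc1ncnc2c1c(-c1ccsc1)cn2[C@@H]1O[C@H](CO)[C@@H](O)[C@H]1O` and compound 2 `COc1nc(N)nc2c1c(-c1ccsc1)cn2[C@@H]1O[C@H](CO)[C@@H](O)[C@H]1O` share one core; compound 2 differs from it by amino in place of hydrogen on an aromatic carbon. In an ADME assay on MRC5 cells (Homo sapiens), read by MTT assay, with a stated time of 72 h (on this read-out lower numbers stand for stronger inhibition and higher numbers for weaker inhibition), compound 1 gives 75300 nM. For compound 2 the same read-out is only a limit, > 100000 nM. The step is an at least 1.3-fold higher number from compound 1 to compound 2 (0.12 log units; that floor lies within the scatter), its floor resting on (the limit of > 100000 nM in this assay, at which 2 of the 3 values shown sit). Compound 3 `O=c1[nH]cnc2c1c(-c1cc3ccccc3o1)cn2[C@@H]1O[C@H](CO)[C@@H](O)[C@H]1O` carries a second core; the difference between the two cores is not broken down here. For compound 3 the result in this assay is also only a limit, > 100000 nM. Compound 4 `Nc1nc2c(c(-c3cc4ccccc4o3)cn2[C@@H]2O[C@H](CO)[C@@H](O)[C@H]2O)c(=O)[nH]1` is still to be measured and differs from compound 3 by amino in place of hydrogen on an aromatic carbon. This is the same kind of change as that from compound 1 to compound 2, though here the place is meta to a group of 1 heavy atom rather than meta to a methoxy group. The step is expected to be a step that the limit leaves unreadable from compound 3 to compound 4 because the measured step of the same kind is an at least 1.3-fold higher number from compound 1 to compound 2 (0.12 log units; that floor lies within the scatter) with its floor set by the limit of > 100000 nM in this assay, at which 2 of the 3 values shown sit. Compound 4 is expected at 150000 nM, between 60000 nM and 400000 nM, most likely reported again as a limit.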

Compound 4, half-maximal inhibitory concentration: > 100000 nM
Compound 4: a limit, no number; the forecaster's own chance of this, stated with the estimate: 80%; the middle value lies beyond the limit too.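

Compound 3 and compound 4 both sit at a limit in this assay, so no step can be read between them: the limit of > 100000 nM in this assay, at which 3 of the 4 values shown sit.

The compounds shown leave open whether amino in place of hydrogen on an aromatic carbon changes this read-out on either core.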